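The compounds below may be only part of what the source reports. "The series", "measured", "known", "first", "only" and "open" are said of these compounds alone.

Measured compounds:
compound 1, `O=C(O)[C@H]1C[C@@H]1c1ccc(NCc2cccc(Oc3ccccc3)c2)cc1`, 88%; 72% (2 entries) 
compound 2, `CN(C)C(=O)CCc1ccc(NCc2cccc(Oc3ccccc3)c2)cc1`, 50% 

In a functional assay on CHO cells for agonist activity at Free fatty acid receptor 1 (Homo sapiens), read by a luciferase reporter (on this read-out higher numbers stand for larger maximal responses and lower numbers for smaller maximal responses), compound 1 gives 88%; 72% (2 entries), as two repeated entries of the several entries of compound 1 in this assay, 88%; 72% (2 entries). Going by the values given here, in the same assay compound 2 gives 50%, which is the only number it has there; one further entry gives no single number. The two values of compound 1 lie within the usual scatter of each other, while compound 2 stands lower than either.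

Compound 3, `CC(C)NC(=O)[C@H]1C[C@@H]1c1ccc(NCc2cccc(Oc3ccccc3)c2)cc1`, has not yet been measured in this assay. It differs from compound 2 by 2-(isopropylcarbamoyl)cyclopropyl in place of 2-(dimethylcarbamoyl)ethyl on an aromatic carbon. Among the compounds with values here, no step between measured compounds of this kind has been recorded, so the size of the change cannot be read from earlier pairs. The carboxylic acid on the same cyclopropane in compound 1 gave 88%; 72% (2 entries), and the open-chain amide of compound 2 gave 50%; a cyclopropane amide is expected to fall between these two. The step of a number 8 percentage points higher from compound 2 to compound 3 (within the scatter) is expected to be small, within or just beyond the scatter. For compound 3 a maximal response of about 58% is expected, with a range from 30% to 85%.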

Compound 3, largest response reached (reported as percent of maximum), in percent of the reference or control that the assay uses: 62%
Compound 3: middle estimate off by 4 percentage points, on the low side; measured number inside the range.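

In this assay, going by these compounds alone, the swap on the aromatic carbon para to a large group gives a number 12 percentage points higher from compound 2 to compound 3 (beyond the scatter), the first step that can be read at this position. It shows that the response moves when this one substituent changes, and that an amide on a cyclopropane, with no carboxylic acid present, still gives a sizeable maximal response. The swap brings in a three-membered ring, an amide hydrogen, an isopropyl group and two defined stereocentres all at once, so the step belongs to the whole change and not to any one of these parts.

How compound 3 compares with the carboxylic acid of compound 1 stays hard to settle, because the readings of that acid spread widely: the several entries of compound 1 in this assay, 88%; 72% (2 entries). Also open, from the compounds shown here alone, is what a dimethylamide on the same cyclopropane, or a carboxylic acid on the open ethyl chain, would give, and either could help separate the effect of the ring from that of the amide.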